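Removing a chloro group from an inactive thiosulfate sulfurtransferase amide

The source may hold more compounds than are shown below. What is called first, only, known or untested is meant among the compounds shown, and "the series" means these compounds.

Compound 2 `O=C(Nc1ccc(Sc2nc3ccccc3s2)c(Cl)c1)c1cccc(Br)c1` stands only at a limit: in an assay on isolated protein for inhibition of thiosulfate sulfurtransferase (Homo sapiens), with a stated time of 60 min, in the absence of a further agent (on this read-out lower numbers stand for stronger inhibition and higher numbers for weaker inhibition), compound 2 gives > 100000 nM, which is a limit of the assay and not a number. Compound 1 `O=C(Nc1ccc(Sc2nc3ccccc3s2)cc1)c1cc(Br)cc(Br)c1` also gives > 100000 nM, again a limit. Compound 3 `O=C(Nc1ccc(Sc2nc3ccccc3s2)cc1)c1cccc(Br)c1` differs from compound 2 by hydrogen in place of chloro on an aromatic carbon. No measured step is available, and both shown values sit at the limit of > 100000 nM in this assay, at which 2 of the 2 values shown sit. Compound 3 is expected to remain near that limit, with a step that the limit leaves unreadable from compound 2 to compound 3 expected to be no step beyond the scatter. Compound 3 is estimated at 150000 nM, between 50000 nM and 500000 nM.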

Compound 3, half-maximal inhibitory concentration: > 100000 nM
Compound 3 was reported as a limit (the forecaster's own chance of this, stated with the estimate: 85%); the middle value lies beyond the limit too.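

No step can be read among compound 1, compound 2 and compound 3 in this assay, as all three stand at a limit and not at a number: the limit of > 100000 nM in this assay, at which 3 of the 3 values shown sit.

From the compounds shown here alone, whether hydrogen in place of chloro or bromo changes inhibition at all remains open.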